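Chloro for Methyl on the Far Ring of Compound 2

The source may hold more compounds than are shown below. What is called first, only, known or untested is meant among the compounds shown, and "the series" means these compounds.

Among the measured compounds shown here, compound 2 `Cc1ccc(-c2ccc(CCC(=O)N3CCCC3)cc2)cc1` stands as the higher of the two numbers measured so far in an assay on HEK293 cells for inhibition of N-acylethanolamine-hydrolyzing acid amidase (Rattus norvegicus), read by LC-MS, with a stated time of 30 min (on this read-out higher numbers stand for weaker inhibition and lower numbers for stronger inhibition), where compound 2 gives 33200 nM. Its nearest neighbour, compound 1 `O=C(CCCCCCc1ccccc1F)N1CCCC1`, gives 13700 nM in this assay, a gap beyond the usual scatter. Compound 3 `O=C(CCc1ccc(-c2ccc(Cl)cc2)cc1)N1CCCC1` differs from compound 2 by chloro in place of methyl on an aromatic carbon. For the measured compounds named here, no measured pair shows this change, so the size of the step is unknown; a shift that stays within the scatter is expected, a 1.5-fold lower number from compound 2 to compound 3 (0.18 log units; within the scatter). Compound 3 is therefore expected to give 22000 nM in this assay, within a range from 8000 nM to 60000 nM.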

Compound 3, half-maximal inhibitory concentration: 48600 nM
Beside the measured number, compound 3's estimate is 2.2-fold (0.34 log units) below it; the measured number falls inside the stated range.
By their numbers in this assay, from the lowest: compound 1; then compounds 2 and 3 (each within the scatter of the next).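

In this assay, chloro in place of methyl, on an aromatic carbon para to a large group, gives a 1.5-fold higher number from compound 2 to compound 3 (0.17 log units; within the scatter), the only reading of this change among the compounds shown. On this read-out, the 4-methylphenyl and 4-chlorophenyl groups therefore cannot be told apart at this position. No independent evidence bears on this result.

Going by these compounds, whether an amine, a carboxylic acid or a methoxy group at this position would give a step beyond the scatter stays open. So does whether the same change would read alike on another core.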